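The source may report more compounds than this note shows. Statements on the series, on what has been measured and on what is new or still open speak of the compounds shown alone.

In a functional assay on MCF7 cells (Homo sapiens) for cytotoxicity, read by MTT assay, with a stated time of 72 h (a higher number here means a weaker inhibitor, a lower number a stronger inhibitor), compound 1 `COc1cc2ncnc(Nc3ccc(F)c(Cl)c3)c2cc1NC(=O)N/N=C/c1ccc(C#N)cc1` stands as "not determined" (no result reported). Going by the values given here, compound 2 `COc1ccc(/C=N/NC(=O)Nc2cc3c(Nc4ccc(F)c(Cl)c4)ncnc3cc2OC)cc1` gives 8140 nM, the one numerical result so far. Compound 3 `COc1cc2ncnc(Nc3ccc(F)c(Cl)c3)c2cc1NC(=O)N/N=C/c1ccc(OC)c(OC)c1OC` has no single number and is recorded as "not active" (no number reported). Compound 4 `CCN(CC)c1ccc(/C=N/NC(=O)Nc2cc3c(Nc4ccc(F)c(Cl)c4)ncnc3cc2OC)c(O)c1` remains unmeasured. It carries 4-(diethylamino)-2-hydroxyphenyl in place of 2,3,4-trimethoxyphenyl on a carbon with a double bond to nitrogen. Among the compounds with values here, no measured step calibrates this exchange, so the size of the step is uncertain. A moderate move from compound 3 towards stronger inhibition is expected in this assay, with compound 2 at 8140 nM as the only numerical anchor. The estimate for compound 4 is 5000 nM, with an expected range of 1000 nM to 25000 nM.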

Compound 4, half-maximal inhibitory concentration: 27300 nM
Compound 4: the middle estimate sits 5.5-fold (0.74 log units) below what was measured, and the stated range ends below it.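

In this assay, going by these compounds alone, 4-(diethylamino)-2-hydroxyphenyl in place of 4-methoxyphenyl on a carbon with a double bond to nitrogen gives a 3.4-fold higher number from compound 2 to compound 4 (0.53 log units; beyond the scatter), the first readable step at this position and a modest loss of strength. Within the data shown here, compound 3 has no single number, so no step to it can be read. Nothing available speaks to the cause of this step.

The compounds shown do not separate the contribution of the diethylamino group from that of the hydroxy group. On these data alone, how a carboxylic acid or a morpholine would fare at this position also remains open.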